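Methyl in place of hydrogen: compound 2 to compound 3

The source may report more compounds than this note shows. Statements on the series, on what has been measured and on what is new or still open speak of the compounds shown alone.

Values so far in a functional assay (strain AB) with Danio rerio as the target, read by microscopy, with a stated time of 1 h (a lower number here means that less compound is needed, a higher number that more compound is needed for the effect), for two compounds:
- compound 1 `CC[N+]1(CC2CC2)CCc2c(sc(NC(=O)Nc3ccc(Cl)cc3)c2C(N)=O)C1` at 100 nM
- compound 2 `CC[N+]1(C)CCc2c(sc(NC(=O)Nc3ccc(Cl)cc3)c2C(N)=O)C1` at 1960 nM

Compound 2 at 1960 nM holds the higher of the two numbers. The change to compound 3 `CC[N+]1(CC)CCc2c(sc(NC(=O)Nc3ccc(Cl)cc3)c2C(N)=O)C1` is methyl in place of hydrogen on a saturated chain carbon bound to an amine nitrogen in a ring, which also reads as methyl to ethyl. Among the compounds with values here, one measured step bears on this place: a 20-fold higher number from compound 1 to compound 2 (1.29 log units; beyond the scatter), with hydrogen in place of cyclopropyl. Read backwards, that large step links a group in place of hydrogen with a lower number. Methyl is not cyclopropyl, so only part of that step is expected to carry over. The estimated shift is a 3.3-fold lower number from compound 2 to compound 3 (0.51 log units; beyond the scatter) in this assay, resting on that single step. Compound 3 is estimated at 600 nM within an expected range of 180 nM to 2000 nM for now.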

Compound 3, half-maximal effective concentration: 450 nM
The estimate for compound 3 lay 1.3-fold (0.12 log units) above the measured number; low and high end bracket the measured number.
By their numbers in this assay, from the lowest: compound 1; then compound 3; then compound 2.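

In this assay a single added methyl at this place, on a saturated chain carbon bound to an amine nitrogen in a ring, already gives a 4.4-fold lower number from compound 2 to compound 3 (0.64 log units; beyond the scatter) and so accounts for part of the earlier large step. The effect therefore does not depend on a ring in this position, since the ethyl of compound 3 also moves the number beyond the scatter. Cyclopropyl still goes further, with a 4.5-fold higher number from compound 1 to compound 3 (0.65 log units; beyond the scatter) as the second modest step, which places compound 3 in the middle of the three compounds. No measured data are available to explain this order.

Still open, from the compounds shown here alone, is whether a longer chain such as propyl or butyl, or a larger ring such as cyclobutyl, would lower the number further or reverse the trend. Going by these compounds, the effect of a hydroxyl or a phenyl on this carbon also remains unknown.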